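The source may report more compounds than this note shows. Statements on the series, on what has been measured and on what is new or still open speak of the compounds shown alone.

Compound 1 `O/N=C(/Nc1ccc(Cl)cc1)c1ccc2occc2c1` gives in an assay on tissue (HeLa cells) for inhibition of Indoleamine 2,3-dioxygenase 1 (Homo sapiens), read by spectrophotometry (on this read-out higher numbers stand for weaker inhibition and lower numbers for stronger inhibition), only a limit of the assay, > 30000 nM.
Compound 2 `O/N=C(/Nc1cccc(Cl)c1)c1ccc2occc2c1` gives 1500 nM.
Compound 3 `O/N=C(/Nc1cccc(Br)c1)c1ccc2occc2c1` gives 1100 nM.

Compound 2 stands highest of the two numbers that are not limits; its nearest neighbour is compound 3, reached by a 1.4-fold lower number from compound 2 to compound 3 (0.13 log units; within the scatter), a step within the scatter. Compound 4 `O/N=C(/Nc1cccc(C(F)(F)F)c1)c1ccc2occc2c1` is not yet measured. It differs from compound 2 by trifluoromethyl in place of chloro on an aromatic carbon. Going by the values given here, the only measured step that bears on this change, a 1.4-fold lower number from compound 2 to compound 3 (0.13 log units; within the scatter), bromo in place of chloro on an aromatic carbon, moved the number within the scatter only, and no measured step has placed a trifluoromethyl on this ring. Compound 4 is therefore expected to show no step beyond the scatter, no change at the digits printed from compound 2 to compound 4 (within the scatter). For compound 4 the estimated value is 1500 nM, with a range from 500 nM to 4500 nM.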

Compound 4, half-maximal inhibitory concentration: 1900 nM
Beside the measured number, compound 4's estimate is 1.3-fold (0.10 log units) below it; the range from low to high includes it.
By their numbers in this assay, from the lowest: compounds 3, 2 and 4 (each within the scatter of the next). At a limit, above all of these: compound 1.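

Trifluoromethyl at this place gives, in this assay, a 1.3-fold higher number from compound 2 to compound 4 (0.10 log units; within the scatter) and a 1.7-fold higher number from compound 3 to compound 4 (0.24 log units; within the scatter). Chloro, bromo and trifluoromethyl thus all give values within the scatter of one another, so the position accepts a group of several heavy atoms as well as a single halogen. Nothing measured here gives a reason for this.

From the compounds shown here alone, whether an amine, a carboxylic acid or a longer chain at this place would stay in the same range remains open. So does how trifluoromethyl would behave on the ring carbon that carries chloro in compound 1.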